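Swapping methyl for methoxy on a thiazole antiproliferative

This account rests on a few compounds, and the source may have more. Where it says the series, first, only, none or still open, it means among the compounds named here.

Measured compounds:
compound 1 `Cc1ccc(Nc2nc(N)c(C(=O)c3ccccc3)s2)cc1` — 370 nM
compound 2 `COc1cc(C(=O)c2sc(Nc3ccc(C)cc3)nc2N)cc(OC)c1OC` — 41 nM
compound 3 `COc1cc(C(=O)c2sc(Nc3ccccc3)nc2N)cc(OC)c1OC` — 9.4 nM

In a functional assay on CCRF-CEM cells (Homo sapiens) for antiproliferative activity, read by cell counting, with a stated time of 2 days (on this read-out lower numbers stand for stronger inhibition and higher numbers for weaker inhibition), compound 1 gives the highest number of the three, so it is the weakest inhibitor here; compound 2 sits well below it and compound 3 lowest of all, both gaps beyond the scatter. For the measured compounds named here, the only single change measured is a 4.4-fold lower number from compound 2 to compound 3 (0.64 log units; beyond the scatter), a modest step that shows the methyl on the six-membered aromatic ring of carbon only can be removed with gain.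

Compound 4 `COc1ccc(Nc2nc(N)c(C(=O)c3ccccc3)s2)cc1` is the unmeasured compound. Its change from compound 1 is methoxy in place of methyl on an aromatic carbon. Going by the values given here, no measured pair shows a methoxy entering at this spot, so the step has no direct precedent. The methyl removal from compound 2 to compound 3 hints that this position tolerates change, but a methoxy adds an atom rather than taking one away, and the other ring differs between those compounds and compound 1. The expectation for compound 4 is therefore a step of a 1.2-fold lower number from compound 1 to compound 4 (0.09 log units; within the scatter), within the scatter or only a little beyond it. Compound 4 is estimated at 300 nM, with a range from 100 nM to 900 nM.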

Compound 4, half-maximal inhibitory concentration: 300 nM
The estimate for compound 4 equals the measured number at the digits printed; low and high end bracket the measured number.
By their numbers in this assay, from the lowest: compound 3; then compound 2; then compounds 4 and 1 (each within the scatter of the next).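

Taking methyl out and putting methoxy in at this spot, on an aromatic carbon para to a large group, gives a 1.2-fold lower number from compound 1 to compound 4 (0.09 log units; within the scatter) in this assay, so compounds 1 and 4 cannot be told apart in this test. For the compounds shown here, the only earlier step, a 4.4-fold lower number from compound 2 to compound 3 (0.64 log units; beyond the scatter), replaced methyl with hydrogen in a different pair and lay beyond the scatter; this new step shows that, on the core of compound 1, a group with one more heavy atom and one hydrogen-bond acceptor can take the place of methyl with no change that can be read. No information on the properties of these groups or on how they act in cells bears on this result, and the numbers alone offer no explanation for it.

Going by these compounds alone, still open is whether methoxy would do the same on the core of compound 2, and whether hydrogen in place of methyl would give compound 1 a step like the one from compound 2 to compound 3. Also open, from the compounds shown here alone, is how this spot would respond to an amine, a carboxylic acid or a longer chain such as ethoxy.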